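A Hydroxymethyl Group on the Pyridin-2-yl of Compound 2

This account rests on a few compounds, and the source may have more. Where it says the series, first, only, none or still open, it means among the compounds named here.

In a functional assay on PC-6 cells (Homo sapiens) for antiproliferative activity (on this read-out lower numbers stand for stronger inhibition and higher numbers for weaker inhibition), compound 1 (`CCc1cc2c(N/N=C\c3cccs3)ncnc2s1`) gives 0.566 ug/mL. Compound 2 (`CC(C)(C)c1cc2c(N/N=C\c3ccccn3)ncnc2s1`) gives 0.009 ug/mL, the lower of the two numbers, with a gap beyond the scatter. These two compounds differ in more than one place, so the gap cannot be assigned to any single change. Compound 3 (`CC(C)(C)c1cc2c(N/N=C\c3cccc(CO)n3)ncnc2s1`) has hydroxymethyl in place of hydrogen on an aromatic carbon of compound 2, next to the ring nitrogen: hydroxymethyl in place of hydrogen on an aromatic carbon. Within the data shown here, no measured pair shows the effect of such a change, so the expectation rests on the structural change alone. A modest move towards weaker inhibition is expected, and it may not clear the scatter. The estimated change is a 2.2-fold higher number from compound 2 to compound 3 (0.35 log units; beyond the scatter). For compound 3 the estimated value is 0.02 ug/mL, with an expected range from 0.004 ug/mL to 0.1 ug/mL.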

Compound 3, half-maximal inhibitory concentration: 0.034 ug/mL
Estimate against measurement, compound 3: 1.7-fold (0.23 log units) below, within the range that was stated.
By their numbers in this assay, from the lowest: compound 2; then compound 3; then compound 1.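

In this assay, hydroxymethyl in place of hydrogen on the aromatic carbon next to the ring nitrogen gives a 3.8-fold higher number from compound 2 to compound 3 (0.58 log units; beyond the scatter), the first step measured at this position. The change from pyridin-2-yl to 6-(hydroxymethyl)pyridin-2-yl weakens inhibition modestly but does not abolish it: compound 3 still gives 0.034 ug/mL. Nothing shown here bears on the reason for this step.

As far as these compounds go, it remains open whether a methyl group, a methoxymethyl group or a carboxylic acid on the same carbon would give a number closer to that of compound 2 or further from it, and so whether the step follows the oxygen or the added carbon of hydroxymethyl. From the compounds shown here alone, it is also open whether hydroxymethyl on another carbon of this ring would carry the same cost.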